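Thiocarbamate benzamide series: pyrrolidine at the thiocarbonyl carbon

The source may report more compounds than this note shows. Statements on the series, on what has been measured and on what is new or still open speak of the compounds shown alone.

Three compounds of the series have numbers in a functional assay on HeLa cells (Homo sapiens) for antiproliferative activity, read by CCK-8 assay, with a stated time of 72 h, tested at 8 uM; on this read-out lower numbers stand for a weaker effect and higher numbers for a stronger effect at the one concentration tested. Compound 1 `Nc1ccccc1NC(=O)c1ccc(CSC(=S)N2CCc3cc([N+](=O)[O-])ccc32)cc1` gives 43.6%. Compound 2 `CN(Cc1cccnc1)C(=S)SCc1ccc(C(=O)Nc2ccccc2N)cc1` gives 68.7%, which lies clearly above compound 1, the gap being beyond the usual scatter. Compound 3 `Nc1ccccc1NC(=O)c1ccc(CSC(=S)N2CCN(c3ccncc3)CC2)cc1` gives 77.4%; its gap to compound 2 falls within the scatter, so no order between these two can be read. Of the three numbers compound 2 therefore holds the second highest, close to compound 3 and well separated from compound 1.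

Compound 4 `Nc1ccccc1NC(=O)c1ccc(CSC(=S)N2CCCC2)cc1` is not yet measured. It differs from compound 2 in one place: pyrrolidin-1-yl in place of methyl((pyridin-3-yl)methyl)amino on a thiocarbonyl carbon. Going by the values given here, no pair of measured compounds shows this change, so the size of the step in this assay cannot be taken from a measured step. A modest downward step is expected, small enough that it may stay within the scatter; the three measured numbers span from compound 1 to compound 3, and compound 4 is expected to land inside that span. Compound 4 is estimated at 60%, with a range from 40% to 78%. The expected step is a number 8.7 percentage points lower from compound 2 to compound 4 (within the scatter).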

Compound 4, a percentage reported as inhibition, at one concentration (the size of the read-out at that concentration, not a potency): 77.8%
Compound 4: middle estimate off by 17.8 percentage points, on the low side; the measured number falls inside the stated range.
By their numbers in this assay, from the lowest: compound 1; then compounds 2, 3 and 4 (each within the scatter of the next).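

In this assay, pyrrolidin-1-yl in place of methyl((pyridin-3-yl)methyl)amino on a thiocarbonyl carbon gives a number 9.1 percentage points higher from compound 2 to compound 4 (within the scatter), so no order between these two compounds can be read. For this pair, the six-membered aromatic ring and its hydrogen-bond acceptor can leave this position without a change beyond the scatter, and the entering group has fewer heavy atoms and a five-membered non-aromatic ring. No measurement on hand gives a reason for this result.

Going by these compounds, whether a piperidine ring, a morpholine ring or a plain dimethylamino group on the same carbon would give a similar read-out remains open. A read-out at a single concentration also leaves open how compound 2 and compound 4 compare in potency.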